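The source may hold more compounds than are shown below. What is called first, only, known or untested is meant among the compounds shown, and "the series" means these compounds.

Measured so far in a physicochemical assay for solubility, read by spectrophotometry, using the shake flask method, with a stated time of 2 days, at pH 6.5; on this read-out higher numbers stand for higher solubility and lower numbers for lower solubility:
- compound 1 `O=C(O)COc1ccc2nc(-c3cn(-c4ccc(O)cc4)nn3)ccc2c1` gives 365 ug/mL
- compound 2 `O=C(O)COc1ccc2nc(-c3cn(-c4ccc(O)c(F)c4)nn3)ccc2c1` gives 37 ug/mL
- compound 3 `O=C(O)COc1ccc2nc(-c3cn(-c4ccccc4)nn3)ccc2c1` gives 1050 ug/mL

Compound 2 stands lowest of these three, and its gaps to both of the others lie beyond the usual scatter. Compound 4 `O=C(O)COCCOc1ccc2nc(-c3cn(-c4ccc(O)c(F)c4)nn3)ccc2c1` has not yet been measured. It keeps the shared core of compound 2 and changes only the acid-bearing chain: (carboxymethoxy)methyl in place of carboxy on a saturated chain carbon bound to an oxygen on an aromatic ring describes the difference, which in words is (carboxymethoxy)methyl in place of carboxy on a saturated chain carbon bound to an oxygen on an aromatic ring.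

The measured steps bear on this only indirectly. There is a 9.9-fold lower number from compound 1 to compound 2 (0.99 log units; beyond the scatter) as a modest step, a 2.9-fold higher number from compound 1 to compound 3 (0.46 log units; beyond the scatter) as another modest one, and a 28-fold higher number from compound 2 to compound 3 (1.45 log units; beyond the scatter) as a large one. All three concern the group on an aromatic nitrogen, and none touches the chain, so they give no direct reading of this change. They do show that single changes in this small set can move the number a long way, which argues for a wide range. With compound 2 at 37 ug/mL as the lowest of the three, a small rise is expected, although the data cannot settle the direction. The estimated change is a 1.5-fold higher number from compound 2 to compound 4 (0.17 log units; within the scatter) and it may well prove to lie within the scatter. For compound 4 the estimated value is 55 ug/mL with an expected range from 15 ug/mL to 200 ug/mL in this assay.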

Compound 4, solubility: 867 ug/mL
The estimate for compound 4 lay 16-fold (1.20 log units) below the measured number, and the stated range ends below it.
By their numbers in this assay, from the lowest: compound 2; then compound 1; then compounds 4 and 3 (each within the scatter of the next).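

In this assay, among these compounds, putting (carboxymethoxy)methyl in place of carboxy on a saturated chain carbon bound to an oxygen on an aromatic ring gives a 23-fold higher number from compound 2 to compound 4 (1.37 log units; beyond the scatter) and so shows that the chain carrying the acid is a place where one change can move this read-out a long way, something the earlier steps could not show because all of them concerned the group on the aromatic nitrogen. Compound 2 and compound 4 share that group on the aromatic nitrogen yet stand far apart, so the number in this pair does not follow from that group alone. Nothing in the data shown accounts for why the number rises with the longer chain.

The compounds shown hold just this one chain change, so it stays open how a still longer chain, or a chain ending in an amine or an amide rather than the carboxylic acid, would read in this assay. Also open, as far as these compounds go, is whether 2-(carboxymethoxy)ethoxy would bring a step of similar size on the cores of compound 1 and compound 3, which carry different groups on the aromatic nitrogen.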